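The source may report more compounds than this note shows. Statements on the series, on what has been measured and on what is new or still open speak of the compounds shown alone.

Working notes on the series in a functional assay on HL-60 cells (Homo sapiens) for cytotoxicity, read by WST assay, with a stated time of 48 h; on this read-out lower numbers stand for an effect already at smaller amounts and higher numbers for an effect only at larger amounts of compound.

Compound 1, `Clc1ccc(C[C@H]2COC[C@@H]2Cc2ccccc2)cc1Cl`, gives 19000 nM in this assay. Among the three measured compounds this is the second highest number. Compound 2, `CCCCOc1ccccc1C[C@H]1COC(=O)[C@@H]1Cc1ccc(Cl)c(Cl)c1`, gives 10000 nM in this assay, a number that sits within the usual scatter of that of compound 1, so no order between the two can be read. Compound 3, `O=C1OC[C@H](Cc2cccc(O)c2)[C@H]1Cc1ccc(Cl)c(Cl)c1`, gives 48000 nM in this assay, a higher number than that of compound 1 and beyond the scatter. Going by the values given here, no pair among the measured compounds differs in a single place, so no step between them is available.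

Compound 4, `Fc1ccc(C[C@H]2COC[C@@H]2Cc2ccc(Cl)c(Cl)c2)cc1`, has not been measured. It differs from compound 1 by fluoro in place of hydrogen on an aromatic carbon. Among the compounds with values here, no measured pair shows the effect of such a change, and the change adds only a single heavy atom. The expectation is therefore a step of a 1.2-fold lower number from compound 1 to compound 4 (0.07 log units; within the scatter), that is, none beyond the scatter. For compound 4 the estimate in this assay is 16000 nM, with a range from 6000 nM to 45000 nM.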

Compound 4, half-maximal effective concentration: 43000 nM
Beside the measured number, compound 4's estimate is 2.7-fold (0.43 log units) below it, and the stated range covers the measured number.
By their numbers in this assay, from the lowest: compounds 2 and 1 (each within the scatter of the next); then compounds 4 and 3 (each within the scatter of the next).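

In this assay, going by these compounds alone, fluoro in place of hydrogen gives the first single-place step: a 2.3-fold higher number from compound 1 to compound 4 (0.35 log units; beyond the scatter), a modest change. The position on the aromatic carbon para to a large group therefore responds to substitution, since one added fluorine atom shifts the effect to larger amounts of compound. Nothing at hand accounts for this shift.

As far as these compounds go, a single step sets no trend, so whether chloro, methoxy or an amine in the same place would raise the number further, leave it unchanged or lower it remains open. From the compounds shown here alone, it is also open whether the phenyl to 4-fluorophenyl change would give a step of similar direction and size on the carbonyl-bearing core of compound 2 or compound 3.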